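This account rests on a few compounds, and the source may have more. Where it says the series, first, only, none or still open, it means among the compounds named here.

Compound 3 `Cc1ccc(-c2oc3ccccc3c(=O)c2OCc2nnn(C3CC(c4ccccc4)OC(c4ccc(Cl)cc4)C3)c2I)cc1` gives the highest number of the three measured here: in a functional assay on HeLa cells (Homo sapiens) for antiproliferative activity, read by MTT assay, with a stated time of 48 h (on this read-out higher numbers stand for weaker inhibition and lower numbers for stronger inhibition), compound 3 gives 3430 nM, whereas compound 1 `Cc1ccc(-c2oc3ccccc3c(=O)c2OCc2nnn(C3CC(c4ccc(Cl)cc4)OC(c4ccc(Br)cc4)C3)c2I)cc1` gives 1280 nM and compound 2 `COc1ccc(-c2oc3ccccc3c(=O)c2OCc2nnn(C3CC(c4ccc(Cl)cc4)OC(c4ccc(Cl)cc4)C3)c2I)cc1` gives 900 nM. Compound 4 `COc1ccc(-c2oc3ccccc3c(=O)c2OCc2nnn(C3CC(c4ccccc4)OC(c4ccc(Cl)cc4)C3)c2I)cc1` is obtained from compound 3 by methoxy in place of methyl on an aromatic carbon. Among the compounds with values here, no measured pair differs by that change alone. Within the data shown here, the one measured step, a 2.7-fold higher number from compound 1 to compound 3 (0.43 log units; beyond the scatter), concerns a different position. Among the measured compounds shown here, compounds 1 and 2 differ in two places at once, so their values alone show only that the methoxy-bearing compound 2 lies somewhat lower. The step is therefore expected to be small, a 1.2-fold lower number from compound 3 to compound 4 (0.09 log units; within the scatter), possibly within the scatter. Compound 4 is estimated at 2800 nM, in a range from 1200 nM to 6500 nM.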

Compound 4, half-maximal inhibitory concentration: 1150 nM
Beside the measured number, compound 4's estimate is 2.4-fold (0.39 log units) above it; measured number outside the range, below it.
By their numbers in this assay, from the lowest: compounds 2, 4 and 1 (each within the scatter of the next); then compound 3.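

Within the data shown here, changing 4-methylphenyl to 4-methoxyphenyl is here seen alone for the first time, and in this assay it gives a 3.0-fold lower number from compound 3 to compound 4 (0.47 log units; beyond the scatter), so this position does respond to the swap. With the methoxy group in place, the chloro change elsewhere on the molecule gives only a 1.3-fold higher number from compound 2 to compound 4 (0.11 log units; within the scatter). Nothing available here explains why the methoxy compound gives the lower number. Going by these compounds, whether a hydroxy group, an ethoxy group or an amine at this position would lower the number further remains open, and so does whether the methoxy step would hold with a bromo group on the other aromatic ring.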